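Caspase-8 series: aryl amide exchange from compound 2 to compound 3

A few compounds are considered here, and "the series" means these few. Any claim that something is new, unique, unknown or untested is made for them only; others in the source may bear on it.

Measured compounds:
- Compound 1 `O=C(CN1CCS(=O)(=O)C[C@H](NC(=O)c2cccc(C(F)(F)F)c2)C1=O)N[C@H]1CC(=O)OC1O`: in an assay on isolated protein for inhibition of Caspase-8 (Homo sapiens) (a higher number here means a weaker inhibitor, a lower number a stronger inhibitor), compound 1 gives "not determined" (no result reported), that is, no result reported.
- Compound 2 `O=C(CN1CCS(=O)(=O)C[C@H](NC(=O)c2cc3ccccc3s2)C1=O)N[C@H]1CC(=O)OC1O`: in this assay compound 2 gives 8500 nM.

For the measured compounds named here, compound 2 therefore carries the only number available in this assay; compound 1 shares the core but has no figure to compare it with, so no step between measured compounds can be drawn and the series gives no measured direction of change.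

Compound 3 `O=C(CN1CCS(=O)(=O)C[C@H](NC(=O)c2nccc3ccccc23)C1=O)N[C@H]1CC(=O)OC1O` differs from compound 2 in a single place: isoquinolin-1-yl in place of 1-benzothiophen-2-yl on a carbonyl carbon. The change exchanges one bicyclic aromatic amide substituent for another of nearly the same heavy-atom count, with the same count of hydrogen-bond donors and acceptors and no change in charge.

With nothing measured to anchor the exchange, the expectation for the step from compound 2 to compound 3 in this assay is no change beyond the usual scatter, expressed as a 1.1-fold lower number from compound 2 to compound 3 (0.03 log units; within the scatter). Compound 3 is accordingly estimated at 8000 nM in this assay, with a range from 2500 nM to 25000 nM reflecting the wide uncertainty of an unanchored exchange.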

Compound 3, half-maximal inhibitory concentration: 5000 nM
Compound 3: middle estimate off by 1.6-fold (0.20 log units), on the high side, within the range that was stated.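

In this assay, for the compounds shown here, the exchange of 1-benzothiophen-2-yl for isoquinolin-1-yl, on a carbonyl carbon whose other neighbour is an amide-type nitrogen, gives a 1.7-fold lower number from compound 2 to compound 3 (0.23 log units; within the scatter) as the first step that can be read. At this position, a bicyclic group with a five-membered aromatic ring holding one hetero atom and a bicyclic group made only of six-membered aromatic rings therefore give values that cannot be told apart from repeat scatter, and neither compound 2 nor compound 3 can be ranked over the other. Nothing available bears on the reason for this outcome.

Steps involving compound 1 cannot be read, as it has no reported value, so this single exchange between two bicyclic aromatic groups is all that describes the position. Still open, as far as these compounds go, is whether an unfused phenyl, a saturated cyclohexyl, or a group carrying a carboxylic acid or an amine on the same carbonyl carbon would stay within the scatter of compound 2 and compound 3, or would move the number clearly away from theirs.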